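Moving the methoxy pattern on the aryl ring of compound 2

The compounds below may be only part of what the source reports. "The series", "measured", "known", "first", "only" and "open" are said of these compounds alone.

Measured compounds:
compound 1 `COc1cccc(/C(=C\c2cn(C(C)=O)c3ccc(OCc4ccccc4)cc23)C(=O)O)c1` gives 1080 nM
compound 2 `COc1cc(/C(=C\c2cn(C(C)=O)c3ccc(OCc4ccccc4)cc23)C(=O)O)cc(OC)c1OC` gives 950 nM

Both compounds were tested in a functional assay on DU-145 cells (Homo sapiens) for cytotoxicity, read by MTT assay, with a stated time of 72 h; on this read-out lower numbers stand for stronger inhibition and higher numbers for weaker inhibition. Compound 2 shows 950 nM and stands at the lowest of the two numbers, with compound 1 nearest; the step of a 1.1-fold lower number from compound 1 to compound 2 (0.06 log units; within the scatter) lies within the scatter. Compound 3 `COc1ccccc1/C(=C\c1cn(C(C)=O)c2ccc(OCc3ccccc3)cc12)C(=O)O` has not yet been measured. It differs from compound 2 in one place: 2-methoxyphenyl in place of 3,4,5-trimethoxyphenyl on a double-bonded chain carbon bound to a carbonyl carbon and a double-bonded chain carbon. Within the data shown here, the only measured step that bears on this change is a 1.1-fold lower number from compound 1 to compound 2 (0.06 log units; within the scatter), which swapped methoxy groups on the same aryl ring and left the number essentially unchanged. The step to compound 3 again alters only the methoxy pattern of that ring, so no movement beyond the scatter is expected in this assay, in either direction. Compound 3 is therefore estimated at 1100 nM, with a range from 500 nM to 2500 nM, which corresponds to an expected step of a 1.2-fold higher number from compound 2 to compound 3 (0.06 log units; within the scatter).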

Compound 3, half-maximal inhibitory concentration: 1010 nM
The estimate for compound 3 lay 1.1-fold (0.04 log units) above the measured number, within the range that was stated.
By their numbers in this assay, from the lowest: compounds 2, 3 and 1 (each within the scatter of the next).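

In this assay the swap to 2-methoxyphenyl gives a 1.1-fold higher number from compound 2 to compound 3 (0.03 log units; within the scatter) when it replaces 3,4,5-trimethoxyphenyl and a 1.1-fold lower number from compound 1 to compound 3 (0.03 log units; within the scatter) when it replaces 3-methoxyphenyl. The earlier pair compared only two methoxy patterns, whereas all three patterns can now be compared, and none can be told apart from the others on this double-bonded chain carbon. This holds even though the group entering compound 3 has fewer heavy atoms and fewer hydrogen-bond acceptors than the group it replaces in compound 2, and nothing measured here explains the flat result.

Every aryl ring shown carries only methoxy groups, so it remains open whether an amine, a hydroxyl group or a chlorine atom on that ring would move the number beyond the scatter. On these data alone, a bare phenyl ring at this place is equally open.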